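Urea series, cytotoxicity read-out: from compound 3 to compound 4

The source may report more compounds than this note shows. Statements on the series, on what has been measured and on what is new or still open speak of the compounds shown alone.

Measured so far:
compound 1 `Cc1cc(NC(=O)Nc2ccc(C)c(Cl)c2)c2ccccc2n1` — > 25000 nM
compound 2 `Cc1cc(NC(=O)Nc2ccc([N+](=O)[O-])c(C(F)(F)F)c2)c2ccccc2n1` — > 25000 nM
compound 3 `Cc1cc(NC(=O)Nc2ncccc2C)c2ccccc2n1` — > 25000 nM

In an ADME assay on Raji cells (Homo sapiens) for cytotoxicity, with a stated time of 72 h (on this read-out lower numbers stand for an effect already at smaller amounts and higher numbers for an effect only at larger amounts of compound), compound 1 gives > 25000 nM, which is a limit of the assay and not a number. Compound 2 gives > 25000 nM, likewise a limit. Compound 3 gives > 25000 nM, again a limit. Among the measured compounds shown here, compound 3 therefore stands where every measured compound of the series stands, at the limit of > 25000 nM in this assay, at which 3 of the 3 values shown sit; no order among the three can be read from these values, and no compound can be called weaker or stronger than another.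

Compound 4 `Cc1cc(NC(=O)Nc2ccc(N)cc2)c2ccccc2n1` has not been measured. It differs from compound 3 as 4-aminophenyl in place of 3-methylpyridin-2-yl on an amide-type nitrogen. For the measured compounds named here, no step between measured compounds covers this change, and no measured compound offers a number rather than a limit to build on. In this assay compound 4 is expected to show no step beyond the scatter, that is a step that the limit leaves unreadable from compound 3 to compound 4, and most probably a limit once more. The estimate for compound 4 is 30000 nM, expected to lie between 8000 nM and 120000 nM.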

Compound 4, half-maximal effective concentration: > 25000 nM
Compound 4 was reported as a limit; the forecaster's own chance of this, stated with the estimate: 80%; the middle value lies beyond the limit too.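

In this assay compound 3 and compound 4 both stand at a limit and not at a number, so no step between them can be read: the limit of > 25000 nM in this assay, at which 4 of the 4 values shown sit.

The compounds shown leave open whether any of the four differs from another in this assay, and at what concentration an effect would appear.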